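Swapping the Halogen-Bearing Ring on the Amide Nitrogen

The compounds below may be only part of what the source reports. "The series", "measured", "known", "first", "only" and "open" are said of these compounds alone.

Of the compounds shown here, three sharing one core have been tested in a functional assay on Huh-7 cells (Homo sapiens) for inhibition, read by MTT assay, with a stated time of 48 h; on this read-out higher numbers stand for weaker inhibition and lower numbers for stronger inhibition. Among the compounds with values here, compound 1 `COc1ccc2c(=O)c(/C=C/C(=O)Nc3ccccc3Cl)coc2c1` is the only one that gives a number: in this assay compound 1 gives 58400 nM. Compound 2 `O=C(/C=C/c1coc2cc(O)ccc2c1=O)NCc1ccc(F)cc1` reaches only a limit, > 100000 nM. Compound 3 `COc1ccc(NC(=O)/C=C/c2coc3cc(O)ccc3c2=O)cc1` likewise stops at a limit, > 100000 nM. The step that the two limits leave unreadable from compound 2 to compound 3 therefore cannot be sized, since both ends sit at the limit of > 100000 nM in this assay, at which 2 of the 3 values shown sit.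

Compound 4 `COc1ccc2c(=O)c(/C=C/C(=O)Nc3ccc(F)cc3)coc2c1` is compound 1 with one change: 4-fluorophenyl in place of 2-chlorophenyl on an amide-type nitrogen. Within the data shown here, none of the measured steps touches this kind of exchange, so no step size can be carried across. The only shown number with this amide substitution pattern is that of compound 1, and a change of one halogenated ring for another of the same size gives no ground to expect movement beyond the usual scatter.

Compound 4 is therefore estimated at 65000 nM, between 25000 nM and 170000 nM, which amounts to an expected step of a 1.1-fold higher number from compound 1 to compound 4 (0.05 log units; within the scatter).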

Compound 4, half-maximal inhibitory concentration: 33900 nM
Beside the measured number, compound 4's estimate is 1.9-fold (0.28 log units) above it; low and high end bracket the measured number.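

In this assay the step of a 1.7-fold lower number from compound 1 to compound 4 (0.24 log units; within the scatter) is the only readable one so far for an exchange on the amide-type nitrogen, since both of its ends are real numbers rather than limits. The two groups cannot be told apart in this measurement, even though 4-fluorophenyl differs from 2-chlorophenyl in both the halogen and where it sits on the ring. Nothing shown here gives a measured reason for this result.

The two compounds cannot show whether the halogen matters at all, so a plain phenyl group on the same nitrogen remains an open comparison. Equally open, as far as these compounds go, is what an amine or a carboxylic acid on that ring would do, or a longer chain in its place.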